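Acyl-guanidine terpenoid amides: growth inhibition notes

The source may report more compounds than this note shows. Statements on the series, on what has been measured and on what is new or still open speak of the compounds shown alone.

Compound 1 `CC(C)=CCC/C(C)=C/CC/C(C)=C/C(=O)NC(=N)N` gives 10000 nM in a functional assay on Hs 683 cells (Homo sapiens) for inhibition, read by MTT assay, with a stated time of 72 h; a higher number here means a weaker inhibitor of growth, a lower number a stronger inhibitor of growth. Compound 2 `CC(C)=CCC/C(C)=C/CC/C(C)=C/C(=O)NC(=N)NC(=O)C=C(C)C`, bearing the additional (2-methylprop-1-en-1-yl)carbonyl group on the amine nitrogen, gives 8300 nM in this assay. Compound 3 `CC(C)=CCC/C(C)=C/C(=O)NC(=N)NC(=O)C=C(C)C`, which carries the shorter chain, gives 31500 nM in this assay.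

The step of a 1.2-fold higher number from compound 2 to compound 1 (0.08 log units; within the scatter) follows the change (hydrogen in place of (2-methylprop-1-en-1-yl)carbonyl on an amine nitrogen). The step of a 3.8-fold higher number from compound 2 to compound 3 (0.58 log units; beyond the scatter) follows the change (hydrogen in place of 3-methylbut-2-en-1-yl on a saturated chain carbon bound to a double-bonded chain carbon), which is also how the core of compound 3 differs from the core of compound 2.

Compound 4 `CC(C)=CCC/C(C)=C/C(=O)NC(=N)N` is not yet measured. It differs from compound 3 by hydrogen in place of (2-methylprop-1-en-1-yl)carbonyl on an amine nitrogen, the same change as from compound 2 to compound 1, with the place described in the same words in both cases. Because the measured step of a 1.2-fold higher number from compound 2 to compound 1 (0.08 log units; within the scatter) lies within the scatter, the expected step for compound 4 is a 1.1-fold higher number from compound 3 to compound 4 (0.06 log units; within the scatter), essentially no change. On that basis compound 4 is expected to give about 36000 nM in this assay, plausibly between 18000 nM and 72000 nM.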

Compound 4, concentration for 50% growth inhibition: 39400 nM
Compound 4: the middle estimate sits 1.1-fold (0.04 log units) below what was measured, within the range that was stated.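

In this assay, removing the (2-methylprop-1-en-1-yl)carbonyl group from the amine nitrogen of the shorter-chain core gives a 1.3-fold higher number from compound 3 to compound 4 (0.10 log units; within the scatter), so this change is as small here as on the longer-chain core: the same change on two cores in this assay, a 1.2-fold higher number (0.08 log units; within the scatter) from compound 2 to compound 1 and a 1.3-fold higher number (0.10 log units; within the scatter) from compound 3 to compound 4, 1.0-fold (0.02 log units) apart, within the scatter of two such steps

Shortening the chain, with hydrogen in place of 3-methylbut-2-en-1-yl, gives a 3.9-fold higher number from compound 1 to compound 4 (0.60 log units; beyond the scatter) on the core without the acyl group, and it carries over at the same size: the same change on two cores in this assay, a 3.8-fold higher number (0.58 log units; beyond the scatter) from compound 2 to compound 3 and a 3.9-fold higher number (0.60 log units; beyond the scatter) from compound 1 to compound 4, 1.0-fold (0.02 log units) apart, within the scatter of two such steps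

These agreements show that each change transfers across the two cores in these four compounds, but they rest on a single pair of cores in a single cell assay and do not show that the same would hold on other cores or in other cells, nor why growth inhibition shifts.

Still open, as far as these compounds go, is whether a longer chain than that of compound 1 would give a further step of the same kind. From the compounds shown here alone, it is equally open whether an acetyl or benzoyl group on the amine nitrogen would leave the number as unchanged as the (2-methylprop-1-en-1-yl)carbonyl group does.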